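The source may hold more compounds than are shown below. What is called first, only, known or untested is meant among the compounds shown, and "the series" means these compounds.

Measured so far:
compound 1, `C/C(=N\OCC(=O)O)c1ccccc1`: < 20%
compound 2, `CC/C(=N\OCC(=O)O)c1ccc(Cl)cc1`: < 20%

In a functional assay on the whole organism for inhibition, with Rattus norvegicus as the target, read by paw edema, with stated times of 1 h and 3 h, at a dose of 50 mg/kg by the oral route (on this read-out lower numbers stand for less inhibition and higher numbers for more inhibition at the one dose given (going by the name of the read-out)), compound 1 gives < 20%, which is a limit of the assay and not a number. In this assay compound 2 gives < 20%, again a limit rather than a number. Among the measured compounds shown here, compound 2 thus stands at the limit of < 20% in this assay, at which 2 of the 2 values shown sit, so the two measured compounds cannot be placed in any order against each other, and no measured step exists from which a trend could be read. Compound 3, `CCCCC/C(=N\OCC(=O)O)c1ccc(Cl)cc1`, carries one change against compound 2: propyl in place of hydrogen on a saturated chain carbon, two bonds along the chain from a carbon with a double bond to nitrogen. With both known values sitting at the limit, there is no measured basis for a direction; the step from compound 2 to compound 3 is expected to be a number at least 2 percentage points higher from compound 2 to compound 3 (that floor lies within the scatter), in the direction of more inhibition if any. Compound 3 is estimated to give 22% in this assay, with a range from 5% to 45%.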

Compound 3, a percentage reported as inhibition, in the whole organism at one dose (the size of the read-out at that dose, not a potency): < 20%
Compound 3 gave a limit, no number (the forecaster's own chance of this, stated with the estimate: 50%); middle value at least 2 percentage points from the limit.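

In this assay compound 3 gives < 20%, a limit of the assay and not a number. Among the compounds shown here, no step from compound 2 to compound 3 can therefore be read: the limit of < 20% in this assay, at which 3 of the 3 values shown sit. The compounds shown leave open whether propyl in place of hydrogen changes inhibition at all, and in which direction.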